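Dropping the chloro from the sulfonyl aryl of compound 2

A few compounds are considered here, and "the series" means these few. Any claim that something is new, unique, unknown or untested is made for them only; others in the source may bear on it.

In an assay on HEK293 cells for displacement of a labelled ligand from 5-hydroxytryptamine receptor 6 (Homo sapiens), with a stated time of 60 min, tested at 0.01 uM, in the presence of a further agent that is not named here (on this read-out lower numbers stand for a weaker effect and higher numbers for a stronger effect at the one concentration tested), compound 2 `COc1ccc(S(=O)(=O)NCCN2CCC(CCC(=O)c3cc(Cl)c(N)cc3OC)CC2)cc1Cl` gives 20%, the higher of the two numbers recorded, though its nearest neighbour compound 1 `COc1cc(N)c(Cl)cc1C(=O)CCC1CCN(CCNS(=O)(=O)c2cc(Br)ccc2Br)CC1` gives 16%, a value within the scatter of it. The third measured compound, compound 3 `COc1ccc(S(=O)(=O)N2CCC(CCC(=O)c3cc(Cl)c(N)cc3OC)CC2)cc1`, carries its 4-methoxyphenyl sulfonyl directly on the piperidine nitrogen and is reported in this assay as "not active" (no number reported), with no number given.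

Compound 4 `COc1ccc(S(=O)(=O)NCCN2CCC(CCC(=O)c3cc(Cl)c(N)cc3OC)CC2)cc1` differs from compound 2 in one place: hydrogen in place of chloro on an aromatic carbon The change sits on the aromatic carbon of the six-membered aromatic ring of carbon only, ortho to a methoxy group, and reads as 3-chloro-4-methoxyphenyl becoming 4-methoxyphenyl.

For the measured compounds named here, the only measured step that bears on this is a number 4 percentage points higher from compound 1 to compound 2 (within the scatter), an exchange of the whole aryl on the sulfonyl sulfur that moved the read-out within the scatter. Because a larger change on this ring gave a number 4 percentage points higher from compound 1 to compound 2 (within the scatter), a smaller one is expected to move the number little, if at all beyond the scatter, with a slight downward lean since compound 3 gives "not active" (no number reported) with the same 4-methoxyphenyl. Compound 4 is therefore estimated at 14%, with a range from 2% to 28%, an expected step of a number 6 percentage points lower from compound 2 to compound 4 (within the scatter).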

Compound 4, a percentage reported as inhibition, at one concentration (the size of the read-out at that concentration, not a potency): 36%
Estimate against measurement, compound 4: 22 percentage points below; measured number outside the range, above it.
By their numbers in this assay, from the lowest: compounds 1 and 2 (each within the scatter of the next); then compound 4.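

In this assay, hydrogen in place of chloro on the aromatic carbon ortho to a methoxy group gives a number 16 percentage points higher from compound 2 to compound 4 (beyond the scatter), so this one atom changes the read-out by more than the scatter, which the exchange of one halogenated aryl for another, a number 4 percentage points higher from compound 1 to compound 2 (within the scatter), did not. The 4-methoxyphenyl also stands clear of the 2,5-dibromophenyl, with a number 20 percentage points higher from compound 1 to compound 4 (beyond the scatter), so among these three compounds it is the aryl without a halogen that separates from the other two. No measurement shown accounts for the rise on losing this chloro.

A fluoro, a methyl or an amine on the same aromatic carbon would show whether the rise belongs to hydrogen at this position or simply to the absence of chloro. Also open, as far as these compounds go, is what separates compound 4 from compound 3, which carries the same 4-methoxyphenyl but is reported as "not active" (no number reported), and a read-out at one concentration gives no potency for either.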